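The source may report more compounds than this note shows. Statements on the series, on what has been measured and on what is new or still open speak of the compounds shown alone.

Working notes on the series.

Compound 1 `CC1(C)Oc2ccc(C#N)cc2[C@@H](/N=C(\NC#N)Nc2ccc(N)cc2)[C@@H]1O` gives 3500 nM in a functional assay (aorta) with Rattus norvegicus as the target; on this read-out lower numbers stand for stronger inhibition and higher numbers for weaker inhibition. Among the three measured compounds it holds the second highest number: compound 2 `CC1(C)Oc2ccc(C#N)cc2[C@@H](NC(=O)Nc2ccncc2)[C@@H]1O` gives 8500 nM, a gap beyond the scatter, while compound 3 `COC(=O)c1cn([C@@H]2c3cc(C#N)ccc3OC(C)(C)[C@H]2O)c2ccccc12` gives 500 nM, the furthest of the three and also beyond the scatter.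

Compound 4 `CSc1ccc(N/C(=N/[C@@H]2c3cc(C#N)ccc3OC(C)(C)[C@H]2O)NC#N)cc1` is not yet measured. It differs from compound 1 in one place: methylsulfanyl in place of amino on an aromatic carbon. Among the measured compounds shown here, no single-point step between measured compounds is available to calibrate this change, so the expectation rests on compound 1 alone. A small step is expected in this assay, a 1.4-fold lower number from compound 1 to compound 4 (0.15 log units; within the scatter), not clearly beyond the scatter. Compound 4 is therefore estimated at 2500 nM, with a range from 800 nM to 8000 nM.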

Compound 4, half-maximal inhibitory concentration: 6300 nM
Beside the measured number, compound 4's estimate is 2.5-fold (0.40 log units) below it; the measured number falls inside the stated range.
By their numbers in this assay, from the lowest: compound 3; then compounds 1, 4 and 2 (each within the scatter of the next, the first and the last beyond it).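

Methylsulfanyl in place of amino on an aromatic carbon, para to a large group, gives a 1.8-fold higher number from compound 1 to compound 4 (0.26 log units; within the scatter) in this assay. This first single-place step in the series shows that this position accepts the larger group, which has no hydrogen-bond donor, with no difference beyond the scatter. Nothing measured here accounts for the step.

Open, going by these compounds, is whether a carboxylic acid, a dimethylamino group or a longer chain such as ethylsulfanyl at this position would also stay within the scatter of compound 1.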